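Truncating the basic sulfonyl chain: expected effect on solubility

The source may hold more compounds than are shown below. What is called first, only, known or untested is meant among the compounds shown, and "the series" means these compounds.

Three compounds of the series have numbers in a physicochemical assay for solubility, at pH 7.4; a higher number here means a more soluble compound, a lower number a less soluble compound. Compound 2 `CN1CCN(CCCS(=O)(=O)c2ccc3nc(NC(=O)NC(=O)c4ccccc4Cl)sc3c2)CC1` gives 280000 nM, the highest number of the three; its nearest neighbour is compound 3 `CC(C)NCCS(=O)(=O)c1ccc2nc(NC(=O)NC(=O)c3ccccc3Cl)sc2c1`, which gives 71000 nM, and the furthest is compound 1 `CS(=O)(=O)c1ccc2sc(NC(=O)NC(=O)c3ccccc3Cl)nc2c1`, which gives 3000 nM, the lowest number of the set. For the measured compounds named here, only one measured pair differs in a single place: a 3.9-fold lower number from compound 2 to compound 3 (0.60 log units; beyond the scatter), where the change is isopropylamino in place of (4-methylpiperazin-1-yl)methyl on a saturated chain carbon, two bonds along the chain from a sulfonyl sulfur.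

Compound 4 `CS(=O)(=O)c1ccc2nc(NC(=O)NC(=O)c3ccccc3Cl)sc2c1` is not yet measured. Relative to compound 2 the change is hydrogen in place of 2-(4-methylpiperazin-1-yl)ethyl on a saturated chain carbon bound to a sulfonyl sulfur. The measured step bears only loosely on this: it swaps one amine for another on the chain and already moves the number by a modest amount, whereas here the whole 2-(4-methylpiperazin-1-yl)ethyl is removed and the sulfonyl ends in a methyl, as it does in compound 1. Going by the values given here, no measured pair shows this removal directly, so the expectation leans on compound 1, which gives 3000 nM. Compound 4 is therefore expected to show a 93-fold lower number from compound 2 to compound 4 (1.97 log units; beyond the scatter). The estimate for compound 4 is 3000 nM, with a range from 700 nM to 13000 nM.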

Compound 4, solubility: < 470 nM
Compound 4: only a limit was reported; the forecaster's own chance of this, stated with the estimate: 10%; middle value at least 6.3-fold (0.80 log units) from the limit.
By their numbers in this assay, from the lowest: compound 1; then compound 3; then compound 2. At a limit, below all of these: compound 4.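

Compound 4 gives only a limit in this assay, not a number: the limit of < 470 nM in this assay, at which 1 of the 4 values shown sits.

Hydrogen in place of the whole 2-(4-methylpiperazin-1-yl)ethyl, on a saturated chain carbon bound to a sulfonyl sulfur, gives an at least 590-fold lower number from compound 2 to compound 4 (2.77 log units; beyond the scatter), a large step, whereas the swap of one amine for another gave only a 3.9-fold lower number from compound 2 to compound 3 (0.60 log units; beyond the scatter). Hydrogen in place of (isopropylamino)methyl at that same carbon gives an at least 150-fold lower number from compound 3 to compound 4 (2.17 log units; beyond the scatter), also large, so among these three compounds, losing the amine-bearing chain moves the number in this assay much further than exchanging one amine for the other does.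

Still open, from the compounds shown here alone, is whether a plain propyl chain with no nitrogen would read close to compound 4 or close to compound 3, which would separate the part played by the chain from that of the amine at its end. Also open, going by these compounds, is how a chain ending in a hydroxyl group or a carboxylic acid, in place of the amine, would read in this assay.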